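Dimethylamino in Place of Hydrogen: What Compound 4 May Show

The compounds below may be only part of what the source reports. "The series", "measured", "known", "first", "only" and "open" are said of these compounds alone.

Compound 1 `CC1=CC[C@H](C(C)(C)N=C=S)CC1` gives > 100000 nM in an ADME assay on Vero cells (Chlorocebus sabaeus) for inhibition, read by sulforhodamine B assay, with a stated time of 48 h (a higher number here means a weaker inhibitor of growth, a lower number a stronger inhibitor of growth), a limit of the assay.
Compound 2 `CC1=CC[C@H](C(C)(C)NC(=S)N/N=C/c2ccccc2)CC1` gives 20500 nM in this assay.
Compound 3 `CC1=CC[C@H](C(C)(C)NC(=S)N/N=C/c2ccc(O)cc2)CC1` gives > 100000 nM in this assay, a limit of the assay.

Among the measured compounds shown here, compound 2 holds the only real number among the three; the other two readings are limits. Compound 4 `CC1=CC[C@H](C(C)(C)NC(=S)N/N=C/c2ccc(N(C)C)cc2)CC1` differs from compound 2 by dimethylamino in place of hydrogen on an aromatic carbon. For the measured compounds named here, the only measured step at the same position is an at least 4.8-fold higher number from compound 2 to compound 3 (0.68 log units; beyond the scatter), where the hydroxy compound reached the limit. Nothing measured shows how a dimethylamino group behaves here, so the expectation rests on that one step and on (the limit of > 100000 nM in this assay, at which 2 of the 3 values shown sit). A weakening step of a 2.4-fold higher number from compound 2 to compound 4 (0.39 log units; beyond the scatter) is expected, with a real chance that compound 4 also sits at the limit. Compound 4 is therefore estimated at 50000 nM in this assay, within 15000 nM to 200000 nM.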

Compound 4, concentration for 50% growth inhibition: 75600 nM
Estimate against measurement, compound 4: 1.5-fold (0.18 log units) below; measured number inside the range.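

A second group on this aromatic carbon, para to a large group, also weakens growth inhibition, and this time the change can be sized: a 3.7-fold higher number from compound 2 to compound 4 (0.57 log units; beyond the scatter). So far, both groups placed here raise the number, and compound 4 gives a real reading that stops short of a ceiling: the limit of > 100000 nM in this assay, at which 2 of the 4 values shown sit. Replacing hydroxy with dimethylamino gives an at least 1.3-fold lower number from compound 3 to compound 4 (0.12 log units; that floor lies within the scatter), so no order can be set between these two groups.

On these data alone, whether fluoro, methoxy or a carboxylic acid on this carbon would also raise the number remains open. So does the effect of dimethylamino on other carbons of the ring.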